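Replacing the acid of compound 1 with a cyclopropyl amide

The source may report more compounds than this note shows. Statements on the series, on what has been measured and on what is new or still open speak of the compounds shown alone.

Compound 1 `Cc1nc(-c2ccc(C(F)(F)F)cc2)sc1CNc1ccc(C(=O)O)cc1` is the weaker of the two measured compounds. In a functional assay on CHO cells for agonist activity at Free fatty acid receptor 1 (Homo sapiens), read by a luciferase reporter (a higher number here means a larger maximal response, a lower number a smaller maximal response), compound 1 gives 10%, while compound 2 `O=C(O)CCCc1ccc(NCc2cccc(Oc3ccccc3)c2)cc1` gives 59%; the gap between them is beyond the usual scatter, so compound 1 stands clearly lower. Within the data shown here, no single-point step between measured compounds is available, so the effect of the change to compound 3 has to be judged from compound 1 alone.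

Compound 3 `Cc1nc(-c2ccc(C(F)(F)F)cc2)sc1CNc1ccc([C@H]2C[C@@H]2C(=O)NC2CCNC2)cc1` differs from compound 1 in one place: 2-((pyrrolidin-3-yl)carbamoyl)cyclopropyl in place of carboxy on an aromatic carbon. The carboxy leaves and a larger group enters on an aromatic carbon, para to a large group.

Since compound 1 already gives 10%, little room remains for a drop, and a rise is not supported by any measured step. The step of a number 5 percentage points higher from compound 1 to compound 3 (within the scatter) is therefore expected to be small, within the scatter. Compound 3 is estimated at 15%, in a range from 0% to 45%.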

Compound 3, largest response reached (reported as percent of maximum), in percent of the reference or control that the assay uses: 52%
Compound 3: middle estimate off by 37 percentage points, on the low side, and the stated range ends below it.
By their numbers in this assay, from the lowest: compound 1; then compounds 3 and 2 (each within the scatter of the next).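

The aromatic carbon para to a large group, which holds carboxy in compound 1, accepts a far larger substituent: in this assay, 2-((pyrrolidin-3-yl)carbamoyl)cyclopropyl in place of carboxy gives a number 42 percentage points higher from compound 1 to compound 3 (beyond the scatter) with the rest of the core unchanged. A carboxy group at this place is therefore not required for a substantial maximal response on this core, and the one-place change alone is enough to produce a large gain. No measured evidence bears on the reason for this gain.

As far as these compounds go, it remains open which part of the entering group carries the gain, since a cyclopropyl bearing a carboxylic acid, or an amide bearing a simple acyclic amine in place of the pyrrolidine, could separate the parts. From the compounds shown here alone, the role of the 2 defined stereocentres also remains open.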